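Removing a Ring Methyl: Expected Solubility of Compound 4

A few compounds are considered here, and "the series" means these few. Any claim that something is new, unique, unknown or untested is made for them only; others in the source may bear on it.

Compound 1 `CC(C)C(/C=C1\OC(=O)NC1=O)c1cc(Cl)c(-c2ccc3cccc(F)c3c2)[nH]c1=O`: 3200 nM
Compound 2 `CC(C)C(c1ccc(-c2ccc3cccc(F)c3c2)[nH]c1=O)C1C(=O)NC(=O)N1C`: 13600 nM
Compound 3 `CCC(/C=C1\OC(=O)NC1=O)(CC)c1ccc(-c2ccc3cccc(F)c3c2)[nH]c1=O`: 13500 nM

In a physicochemical assay for solubility, measured as kinetic solubility, at pH 2 (on this read-out higher numbers stand for higher solubility and lower numbers for lower solubility), compound 2 gives 13600 nM, the highest of the three numbers. Its value and that of compound 3 lie within the scatter of each other, so nothing separates them, while compound 1 sits beyond the scatter below compound 2. Compound 4 `CC(C)C(c1ccc(-c2ccc3cccc(F)c3c2)[nH]c1=O)C1NC(=O)NC1=O` differs from compound 2 in one place: hydrogen in place of methyl on an amide-type nitrogen in a ring. Among the measured compounds shown here, no pair of measured compounds shows what this change does on its own. A step of modest size is expected, most likely none beyond the scatter, with no firm direction. Compound 4 is therefore estimated at 12000 nM, with a range from 5000 nM to 30000 nM. That estimate means an expected step of a 1.1-fold lower number from compound 2 to compound 4 (0.05 log units; within the scatter).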

Compound 4, solubility: 5800 nM
Beside the measured number, compound 4's estimate is 2.1-fold (0.32 log units) above it, within the range that was stated.
By their numbers in this assay, from the lowest: compounds 1 and 4 (each within the scatter of the next); then compounds 3 and 2 (each within the scatter of the next).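

Hydrogen in place of methyl on an amide-type nitrogen in a ring brings a 2.3-fold lower number from compound 2 to compound 4 (0.37 log units; beyond the scatter) in this assay and gives the first direct reading of this change. Although only one carbon leaves, the step lies beyond the scatter, with the methyl compound on the higher side. The data offer no explanation for this step. Still open, going by these compounds, is whether an ethyl group or a longer chain on this nitrogen would give a higher or lower number than methyl. An amine or a carboxylic acid at the end of such a chain is equally unexplored here.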